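The compounds below may be only part of what the source reports. "The series", "measured", "known", "first", "only" and "open" are said of these compounds alone.

Going by the values given here, in an assay on isolated protein for inhibition of acyl-CoA desaturase 1 (Rattus norvegicus) (a lower number here means a stronger inhibitor, a higher number a weaker inhibitor), compound 2 `CS(=O)(=O)c1ccc2nc(-c3ccc(-c4cccc(F)c4)cc3)[nH]c2c1` gives 21 nM, the only finished number among the two results recorded here. Compound 1 `N#Cc1ccc2nc(-c3ccc(-c4ccccc4F)cc3)[nH]c2c1` differs from compound 2 in more than one place. In this assay compound 1 is reported only as > 20000 nM, which is a limit of the assay rather than a measured number. The two results thus sit at opposite ends of what this small set has shown: one strong inhibitor and one reading at the assay limit (the limit of > 20000 nM in this assay, at which 1 of the 2 values shown sits). Compound 3 `CS(=O)(=O)c1ccc2nc(-c3ccc(-c4ccccn4)cc3)[nH]c2c1` has not yet been measured. It differs from compound 2 by pyridin-2-yl in place of 3-fluorophenyl on an aromatic carbon. Among the compounds with values here, no measured pair of compounds differing in a single place is available to guide the size of this change, so the expected step is a 1.9-fold higher number from compound 2 to compound 3 (0.28 log units; within the scatter), modest and without a clear direction beyond the usual scatter. Compound 3 is therefore estimated at 40 nM, within a range of 10 nM to 200 nM.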

Compound 3, half-maximal inhibitory concentration: 1710 nM
Compound 3: middle estimate off by 43-fold (1.63 log units), on the low side, and the stated range ends below it.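

Going by these compounds alone, this is the first step in the set that can be read at a single place, and it shows that the group on this aromatic carbon, para to a large group, matters greatly in this assay: pyridin-2-yl in place of 3-fluorophenyl gives an 81-fold higher number from compound 2 to compound 3 (1.91 log units; beyond the scatter). Keeping a six-membered aromatic ring is therefore not enough to keep the inhibition, even though the entering ring differs only by carrying a ring nitrogen, a hydrogen-bond acceptor, and no fluorine. Nothing measured here explains why the step is so large.

Still open, from the compounds shown here alone, is whether the loss of the fluorine or the arrival of the ring nitrogen carries the step, and a plain phenyl on this carbon would help separate the two. Going by these compounds, how pyridin-3-yl or pyridin-4-yl would compare also remains open.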